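The source may hold more compounds than are shown below. What is called first, only, known or untested is meant among the compounds shown, and "the series" means these compounds.

Within the data shown here, of the two compounds measured so far, compound 2 `COc1cc2c(cc1C)NC(=O)/C2=C/c1c(Cl)n(Cc2cc(OC)c(OC)c(OC)c2)c2cc(C)c(OC)cc12` gives the highest number in a functional assay on cells (Cancer cell lines, Homo sapiens) for cytotoxicity, with a stated time of 48 h; a higher number here means a weaker inhibitor of growth, a lower number a stronger inhibitor of growth: compound 2 gives 38900 nM, whereas compound 1 `COc1cc2c(/C=C3/C(=O)Nc4ccc(O)cc43)c(Cl)n(Cc3cc(OC)c(OC)c(OC)c3)c2cc1C` gives 2750 nM, a gap beyond the usual scatter. Compound 3 `COc1ccc2c(c1)/C(=C\c1c(Cl)n(Cc3cc(OC)c(OC)c(OC)c3)c3cc(C)c(OC)cc13)C(=O)N2` is the next compound, and it differs from compound 2 by hydrogen in place of methyl on an aromatic carbon. Among the measured compounds shown here, no measured pair of compounds shows this change, so the expected step is small, a 1.1-fold lower number from compound 2 to compound 3 (0.05 log units; within the scatter), in no clear direction and within the scatter. Compound 3 is therefore estimated at 35000 nM, with a range from 12000 nM to 100000 nM.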

Compound 3, concentration for 50% growth inhibition: 29500 nM
The estimate for compound 3 lay 1.2-fold (0.07 log units) above the measured number; the range from low to high includes it.
By their numbers in this assay, from the lowest: compound 1; then compounds 3 and 2 (each within the scatter of the next).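

In this assay, hydrogen in place of methyl on this aromatic carbon, ortho to a methoxy group, leaves the result within the scatter, with a 1.3-fold lower number from compound 2 to compound 3 (0.12 log units; within the scatter) as the step. Methyl in place of hydrogen on the oxygen on the aromatic ring, however, gives an 11-fold higher number from compound 1 to compound 3 (1.03 log units; beyond the scatter) as a large step, so in these compounds that oxygen's hydrogen counts for far more than the methyl on carbon. No measurement shown here explains either step.

Going by these compounds, whether an amine in place of the hydroxyl, or a longer chain on that oxygen, would stay close to compound 1 or to compound 3 remains open.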